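Swapping benzyloxy for bromo where every value is a limit

This account rests on a few compounds, and the source may have more. Where it says the series, first, only, none or still open, it means among the compounds named here.

Measured so far in an ADME assay on Raji cells (Homo sapiens) for cytotoxicity, read by luminescence, with a stated time of 72 h; a lower number here means that less compound is needed, a higher number that more compound is needed for the effect:
compound 1 `C=Cc1cccc(-c2[nH]c3cc(OC)ccc3c(=O)c2C(=O)OCC)c1` – > 21500 nM (a limit)
compound 2 `CCOC(=O)c1c(-c2cccc(OCC(C)C)c2)[nH]c2cc(OC)ccc2c1=O` – > 21500 nM (a limit)
compound 3 `CCOC(=O)c1c(-c2cccc(OCc3ccccc3)c2)[nH]c2cc(OC)ccc2c1=O` – > 21500 nM (a limit)

Compound 3 gives > 21500 nM, which is a limit and not a number. It therefore offers no exact starting point, and the same is true of the whole set, as shown by the limit of > 21500 nM in this assay, at which 3 of the 3 values shown sit.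

The next compound, compound 4 `CCOC(=O)c1c(-c2cccc(Br)c2)[nH]c2cc(OC)ccc2c1=O`, carries bromo in place of benzyloxy on an aromatic carbon.

Three measured steps change the group at this place or within it. They are a step that the two limits leave unreadable from compound 1 to compound 2, a step that the two limits leave unreadable from compound 1 to compound 3 and a step that the two limits leave unreadable from compound 2 to compound 3. None of them has a size that can be used, and none contains bromo. Still, vinyl, isobutoxy and benzyloxy all end at the same limit in this assay, so no step in either direction can be predicted.

The expected change is a number no higher from compound 3 to compound 4 (the limit leaves the size open), which means no shift beyond the usual scatter. The most likely outcome is that the assay again reports only a limit. For compound 4 the estimated value is 21500 nM, with an expected range of 10000 nM to 43000 nM.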

Compound 4, half-maximal effective concentration: > 21500 nM
Compound 4: a limit, no number; the forecaster's own chance of this, stated with the estimate: 85%; the middle value lies on the limit itself.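

In this assay compound 4 gives > 21500 nM, which is a limit and not a number. No step among compound 1, compound 2, compound 3 and compound 4 can be read, because all four end at the same limit: the limit of > 21500 nM in this assay, at which 4 of the 4 values shown sit.

The compounds shown leave open whether vinyl, isobutoxy, benzyloxy and bromo differ at all in this assay.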